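This account rests on a few compounds, and the source may have more. Where it says the series, first, only, none or still open, it means among the compounds named here.

Of the compounds shown here, three from one series have been tested in a functional assay on MCF7 cells (Homo sapiens) for antiproliferative activity, read by MTT assay, with a stated time of 48 h; a higher number here means a weaker inhibitor, a lower number a stronger inhibitor. Compound 1 `COc1cc(/C=N/c2c(C#N)ncn2-c2ccc(F)cc2)cc(OC)c1OC` gives 8320 nM. Compound 2 `COc1ccc(OC)c(/C=N/c2c(C#N)ncn2-c2ccc(F)cc2)c1` gives 7090 nM; how its core differs from that of compound 1 is not broken down here. Compound 3 `COc1cc(/C=N/c2c(C#N)ncn2Cc2ccc(F)cc2)cc(OC)c1OC` gives 9040 nM. Compound 3 arises from compound 1 by one change, (4-fluorobenzyl in place of 4-fluorophenyl on an aromatic nitrogen), and this step gave a 1.1-fold higher number from compound 1 to compound 3 (0.04 log units; within the scatter). The three numbers sit close together, so none of the three can be called stronger or weaker than another.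

Compound 4 `COc1ccc(OC)c(/C=N/c2c(C#N)ncn2Cc2ccc(F)cc2)c1` is not yet measured. It arises from compound 2 by the same change, (4-fluorobenzyl in place of 4-fluorophenyl on an aromatic nitrogen), at a place described in the same words as for compound 1 and compound 3. Because the earlier step gave a 1.1-fold higher number from compound 1 to compound 3 (0.04 log units; within the scatter), the step expected for compound 4 is a 1.1-fold higher number from compound 2 to compound 4 (0.04 log units; within the scatter). On that basis compound 4 is estimated to give 7800 nM in this assay, with the expected range running from 4500 nM to 14000 nM.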

Compound 4, half-maximal inhibitory concentration: 10900 nM
Estimate against measurement, compound 4: 1.4-fold (0.15 log units) below; low and high end bracket the measured number.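

In this assay placing 4-fluorobenzyl instead of 4-fluorophenyl on the aromatic nitrogen gave a 1.5-fold higher number from compound 2 to compound 4 (0.19 log units; within the scatter) on the second core. Set beside the earlier step, the change behaves alike on both cores as far as these numbers can tell: the same change on two cores in this assay, a 1.1-fold higher number (0.04 log units; within the scatter) from compound 1 to compound 3 and a 1.5-fold higher number (0.19 log units; within the scatter) from compound 2 to compound 4, 1.4-fold (0.15 log units) apart, within the scatter of two such steps. So, in these two pairs, the change carries from the core of compound 1 to the core of compound 2 with no difference that can be told from ordinary assay noise, but neither step shows that the change truly moves activity on either core, and two pairs make no rule for other cores in the series.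

The compounds shown leave open how this assay responds to a group on that nitrogen that differs more from these two, such as a longer chain like 2-phenylethyl or a chain ending in an amine. They also leave open whether the same step would hold on a core carrying a carboxylic acid in place of the cyano group.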